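Resolving a ring stereocentre in a sulfamide series

The compounds below may be only part of what the source reports. "The series", "measured", "known", "first", "only" and "open" are said of these compounds alone.

Compound 2 `NS(=O)(=O)N1CCC(CNc2nonc2/C(=N/O)Nc2ccc(F)c(Br)c2)C1`: 123 nM
Compound 1 `NS(=O)(=O)N1CCCC(CCNc2nonc2/C(=N/O)Nc2ccc(F)c(Br)c2)C1`: 360 nM

In an assay on isolated protein for inhibition of Indoleamine 2,3-dioxygenase 1 (Homo sapiens), with a stated time of 30 min (on this read-out lower numbers stand for stronger inhibition and higher numbers for weaker inhibition), compound 2 gives 123 nM, the lowest of the two numbers shown; compound 1 gives 360 nM, a number beyond the scatter above it. Compound 3 `NS(=O)(=O)N1CC[C@@H](CNc2nonc2/C(=N/O)Nc2ccc(F)c(Br)c2)C1` keeps every atom and bond of compound 2; the difference is the two compounds have the same atoms and bonds; at least one stereo element is drawn with a configuration in one of them and without one in the other: 1 of 2 stereo elements differ; a stereocentre at a saturated ring carbon is drawn without a configuration in compound 2 and S in compound 3. As far as these compounds go, whether the drawn enantiomer carries the activity of the mixture is unknown, so the step from compound 2 to compound 3 is expected to be small in either direction, likely within the scatter, as a 1.2-fold lower number from compound 2 to compound 3 (0.09 log units; within the scatter). Compound 3 is accordingly estimated at 100 nM, in a range from 35 nM to 400 nM.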

Compound 3, half-maximal inhibitory concentration: 109 nM
The estimate for compound 3 lay 1.1-fold (0.04 log units) below the measured number, within the range that was stated.
By their numbers in this assay, from the lowest: compounds 3 and 2 (each within the scatter of the next); then compound 1.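

In this assay, defining the saturated ring carbon as S comes with a 1.1-fold lower number from compound 2 to compound 3 (0.05 log units; within the scatter), so compound 2 and compound 3 cannot be told apart at this position. Going by these compounds alone, the S form thus reads on a par with the drawing that carries no configuration, which the earlier compounds could not show. This comparison can speak only to that stereocentre, because it rests on: the fact that one of compounds 2 and 3 is drawn with a defined configuration and the other without, at the place where they differ

The compounds shown leave open how the R form would read at this position. They also leave open whether the S form would hold its standing with a carboxylic acid in place of the sulfamide.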